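The source may report more compounds than this note shows. Statements on the series, on what has been measured and on what is new or still open speak of the compounds shown alone.

For the measured compounds named here, in a functional assay on L02 cells (Homo sapiens) for inhibition, read by Griess assay, with stated times of 1 h and 24 h (a lower number here means a stronger inhibitor, a higher number a weaker inhibitor), compound 3 `COc1cc(/C=C/c2nc(N(C)c3ccccc3)c3sccc3n2)cc(OC)c1OC` gives 767000 nM, the only actual number among the three measured compounds. Compound 1 `COc1cc(/C=C/c2nc(NC3CC3)c3sccc3n2)cc(OC)c1OC` reaches only the limit > 1000000 nM. Compound 2 `COc1cc(/C=C/c2nc(N3CCN(C)CC3)c3sccc3n2)cc(OC)c1OC` likewise sits at the limit > 1000000 nM. The readable steps, an at least 1.3-fold lower number from compound 1 to compound 3 (0.11 log units; that floor lies within the scatter) and an at least 1.3-fold lower number from compound 2 to compound 3 (0.11 log units; that floor lies within the scatter), each rest on a floor within the scatter, while a step that the two limits leave unreadable from compound 1 to compound 2. Compound 4 `COc1cc(/C=C/c2nc(NCc3ccc(Cl)cc3)c3sccc3n2)cc(OC)c1OC` carries (4-chlorobenzyl)amino in place of methyl(phenyl)amino on an aromatic carbon. Every exchange so far at the same aromatic carbon, across compounds 1, 2 and 3, has yielded either a limit or a number near it, so no step beyond the scatter is expected in this assay, and a limit is a real possibility. For compound 4 one expects 900000 nM, within 300000 nM to 3000000 nM. The expected step is a 1.2-fold higher number from compound 3 to compound 4 (0.07 log units; within the scatter).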

Compound 4, half-maximal inhibitory concentration: > 1000000 nM
Compound 4 was reported as a limit; the forecaster's own chance of this, stated with the estimate: 45%; middle value at least 1.1-fold (0.04 log units) from the limit.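

In this assay, (4-chlorobenzyl)amino, which brings a chlorine and a hydrogen-bond donor to this aromatic carbon, gives an at least 1.3-fold higher number from compound 3 to compound 4 (0.11 log units; that floor lies within the scatter), and this is only a floor because the value of compound 4 is a limit. The steps from compound 1 and compound 2 to compound 4 cannot be read. A third, different amine thus lands at the same limit, leaving compound 3 as the only one with a number: the limit of > 1000000 nM in this assay, at which 3 of the 4 values shown sit.

As far as these compounds go, whether a morpholine, a carboxylic acid or a longer chain at this carbon would give a number well clear of that limit stays open.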